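Fluorine for methoxy on the pendant phenyl of compound 3

A few compounds are considered here, and "the series" means these few. Any claim that something is new, unique, unknown or untested is made for them only; others in the source may bear on it.

Measured compounds in a functional assay on QG-56 cells (Homo sapiens) for antiproliferative activity; on this read-out lower numbers stand for stronger inhibition and higher numbers for weaker inhibition:
- compound 1 `Cn1cncc1C(O)(c1ccc(C#N)cc1)c1cc2cc([N+](=O)[O-])cc(-c3ccccc3)c2o1` gives 1480 nM
- compound 2 `COc1ccc(-c2cc([N+](=O)[O-])cc3cc(C(O)(c4ccc(C#N)cc4)c4cncn4C)oc23)cc1` gives 36 nM
- compound 3 `COc1cccc(-c2cc([N+](=O)[O-])cc3cc(C(O)(c4ccc(C#N)cc4)c4cncn4C)oc23)c1` gives 38.8 nM

Compound 3 holds the second highest of the three numbers in this assay; its nearest neighbour is compound 2, and the two differ only by a 1.1-fold higher number from compound 2 to compound 3 (0.03 log units; within the scatter), a gap within the scatter. The furthest is compound 1, which stands above it by a 38-fold lower number from compound 1 to compound 3 (1.58 log units; beyond the scatter).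

Compound 4 `Cn1cncc1C(O)(c1ccc(C#N)cc1)c1cc2cc([N+](=O)[O-])cc(-c3ccc(F)cc3)c2o1` has not yet been measured. It differs from compound 3 in one place: 4-fluorophenyl in place of 3-methoxyphenyl on an aromatic carbon.

Within the data shown here, two measured steps bear on this change. The gain of a methoxy on the pendant phenyl, a 41-fold lower number from compound 1 to compound 2 (1.61 log units; beyond the scatter) and a 38-fold lower number from compound 1 to compound 3 (1.58 log units; beyond the scatter), was large, and moving that methoxy between the two ring positions, a 1.1-fold higher number from compound 2 to compound 3 (0.03 log units; within the scatter), changed nothing beyond the scatter. Among the measured compounds shown here, no measured compound carries a fluorine on that ring, so the data say nothing directly about 4-fluorophenyl. Since compound 4 loses the methoxy that separated compound 3 from compound 1 by a 38-fold lower number from compound 1 to compound 3 (1.58 log units; beyond the scatter), a higher number than compound 3 is expected, though likely not all the way back to the level of compound 1. The estimated step is a 7.7-fold higher number from compound 3 to compound 4 (0.89 log units; beyond the scatter). Compound 4 is estimated at 300 nM, within the range 60 nM to 1500 nM.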

Compound 4, half-maximal inhibitory concentration: 158 nM
For compound 4 the middle estimate is 1.9-fold (0.28 log units) above the measured one, and the stated range covers the measured number.
By their numbers in this assay, from the lowest: compounds 2 and 3 (each within the scatter of the next); then compound 4; then compound 1.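

In this assay, among these compounds, methoxy is not the only group on the pendant phenyl that lowers the number: fluoro in place of hydrogen gives a 9.4-fold lower number from compound 1 to compound 4 (0.97 log units; beyond the scatter), so a single fluorine already recovers part of the gain seen with methoxy. Fluoro still falls short of methoxy at the same ring position, with a 4.4-fold higher number from compound 2 to compound 4 (0.64 log units; beyond the scatter), and the comparison with the other methoxy compound gives a similar a 4.1-fold higher number from compound 3 to compound 4 (0.61 log units; beyond the scatter), although that step changes both the group and its ring position, so the order among these substituents runs from hydrogen through fluoro to methoxy for the compounds shown. No measured information accounts for this order of groups.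

Going by these compounds, the position of the fluorine remains open: only methoxy has been compared at two ring positions, and whether 3-fluorophenyl would match 4-fluorophenyl as closely cannot be told from these compounds. It also remains to be seen how other groups on the pendant phenyl, such as an amine, a carboxylic acid, a trifluoromethyl or a longer ethoxy chain, would compare with fluoro and methoxy.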